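Cytotoxicity notes on three measured compounds and one pending

The source may hold more compounds than are shown below. What is called first, only, known or untested is meant among the compounds shown, and "the series" means these compounds.

Measured compounds and their values:
compound 1, `O=C(COc1cccc2ccccc12)N/N=C/c1ccc(Cl)cc1` — 100 ug/mL
compound 2, `O=C(COc1cccc2ccccc12)N/N=C/c1ccc([N+](=O)[O-])cc1` — 20 ug/mL
compound 3, `O=C(COc1cccc2ccccc12)N/N=C/c1ccccc1Cl` — 100 ug/mL

All three share one core and differ only in the aryl group on the carbon with a double bond to nitrogen. In an ADME assay on HEL cells (Homo sapiens) for cytotoxicity (on this read-out lower numbers stand for higher toxicity in this test and higher numbers for lower toxicity in this test), compound 1 gives 100 ug/mL. Compound 2 carries nitro in place of chloro on an aromatic carbon, and the step of a 5.0-fold lower number from compound 1 to compound 2 (0.70 log units; beyond the scatter) is the only one in the set that lies beyond the scatter. Compound 3 carries 2-chlorophenyl in place of 4-chlorophenyl on a carbon with a double bond to nitrogen; the step of no change at the digits printed from compound 1 to compound 3 (within the scatter) means that compound 1 and compound 3 cannot be told apart in this assay, and together they hold the highest numbers of the three. Going by the values given here, no step between compound 2 and compound 3 is broken down here; their two values alone show compound 2 at a lower number.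

Compound 4, `O=C(COc1cccc2ccccc12)N/N=C/c1ccccc1[N+](=O)[O-]`, is not yet measured. It differs from compound 3 by nitro in place of chloro on an aromatic carbon. Among the compounds with values here, this is the same kind of change as the one from compound 1 to compound 2, but not the same: in compound 2 the nitro stands para to a large group, in compound 4 it stands ortho to a large group. Nothing in the measured set shows how this change behaves at the ortho position, so the expectation rests only on compound 1 and compound 2.

Compound 4 is expected to give 25 ug/mL in this assay, with a range from 10 ug/mL to 100 ug/mL. Within the data shown here, the estimated step of a 4.0-fold lower number from compound 3 to compound 4 (0.60 log units; beyond the scatter) is set beside the measured step because a 5.0-fold lower number from compound 1 to compound 2 (0.70 log units; beyond the scatter) is the only guide available; the range is kept wide since the change from compound 3 to compound 4 sits at a different place on the ring and the earlier step could fail to carry over.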

Compound 4, minimum cytotoxic concentration: 20 ug/mL
Compound 4: middle estimate off by 1.3-fold (0.10 log units), on the high side, within the range that was stated.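

In this assay, nitro in place of chloro on an aromatic carbon again lowers the number, with a 5.0-fold lower number from compound 3 to compound 4 (0.70 log units; beyond the scatter), and this step matches the earlier one within the scatter: the same change on two cores in this assay, a 5.0-fold lower number (0.70 log units; beyond the scatter) from compound 1 to compound 2 and a 5.0-fold lower number (0.70 log units; beyond the scatter) from compound 3 to compound 4, 1.0-fold (0.00 log units) apart, within the scatter of two such steps. The change therefore carries across the two chlorophenyl starting points shown, the 4-chlorophenyl and the 2-chlorophenyl, and moving the substituent on the aromatic ring does not detectably alter the size of the step in this read-out. Going by these compounds alone, this rests on only two pairs that share the rest of their structure in a single cell assay, so it does not show that the step would hold on a core altered elsewhere, and it gives no explanation for the lower numbers seen with nitro.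

The compounds shown leave open whether an amine or a carboxylic acid on the aromatic ring would give a number like that of chloro or like that of nitro. They also leave open whether the nitro-for-chloro step survives a change elsewhere in the shared core, such as a longer chain linking the ether oxygen to the carbonyl.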